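The source may hold more compounds than are shown below. What is called first, only, known or untested is meant among the compounds shown, and "the series" means these compounds.

Measured compounds:
- compound 1 `CCCCCNNC(=O)c1ccc(-c2ccc(CNC(C)=O)cc2)cc1`: 350 nM
- compound 2 `CCCNNC(=O)c1cnc(N2CCN(Cc3c[nH]c4ccccc34)CC2)nc1`: 8.2 nM
- compound 3 `CCCCCCNNC(=O)c1ccc(-c2ccc(CNC(C)=O)cc2)cc1`: 36 nM

In an assay on isolated protein for inhibition of histone deacetylase 8 (Homo sapiens), read by fluorescence, with a stated time of 5 min (on this read-out higher numbers stand for weaker inhibition and lower numbers for stronger inhibition), compound 2 gives the lowest of the three numbers. Its nearest neighbour is compound 3, which gives 36 nM, and the furthest is compound 1, which gives 350 nM; both gaps lie beyond the scatter.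

Compound 4 `CCCCCCNNC(=O)c1cnc(N2CCN(Cc3c[nH]c4ccccc34)CC2)nc1` is not yet measured. It differs from compound 2 in one place: propyl in place of hydrogen on a saturated chain carbon, three bonds along the chain from an amine nitrogen. For the measured compounds named here, one measured step bears on this change, the lengthening of the same kind of chain between compound 1 and compound 3, which gave a 9.7-fold lower number from compound 1 to compound 3 (0.99 log units; beyond the scatter). That step adds only a single carbon, whereas the change to compound 4 adds three, and it starts from compound 1, a weaker compound than compound 2. Going by the values given here, the one comparison available points to a lower number with a longer chain, so a step in the same direction is expected, but of smaller size, since compound 2 already gives 8.2 nM. The expected step from compound 2 to compound 4 is a 2.7-fold lower number from compound 2 to compound 4 (0.44 log units; beyond the scatter). Compound 4 is therefore estimated at 3 nM, with a range from 0.8 nM to 12 nM.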

Compound 4, half-maximal inhibitory concentration: 5.9 nM
Beside the measured number, compound 4's estimate is 2.0-fold (0.29 log units) below it; measured number inside the range.
By their numbers in this assay, from the lowest: compounds 4 and 2 (each within the scatter of the next); then compound 3; then compound 1.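

In this assay, propyl in place of hydrogen on a saturated chain carbon, three bonds along the chain from an amine nitrogen, gives a 1.4-fold lower number from compound 2 to compound 4 (0.14 log units; within the scatter), so compound 2 and compound 4 cannot be told apart on this read-out. For the compounds shown here, the only chain step seen earlier, a 9.7-fold lower number from compound 1 to compound 3 (0.99 log units; beyond the scatter), lies beyond the scatter, so the result shows that lengthening this kind of chain does not give a step beyond the scatter on every core: on the core of compound 2, the longer hexyl chain leaves the number within the scatter. No measurement offered here explains why the two steps differ in this way.

The compounds shown leave open whether a butyl or pentyl chain on the core of compound 2 would also stay within the scatter of compound 2, or whether a chain longer than hexyl would move beyond it. From the compounds shown here alone, it also remains open how this position would respond to a chain ending in a hydroxyl group, an amine or a phenyl ring.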